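From 4-fluorophenyl to pyridin-3-yl on compound 1

This account rests on a few compounds, and the source may have more. Where it says the series, first, only, none or still open, it means among the compounds named here.

Measured in a functional assay on MCF7 cells (Homo sapiens) for cytotoxicity, read by WST assay, with a stated time of 72 h; a higher number here means a weaker inhibitor, a lower number a stronger inhibitor:
compound 1 `O=C1Nc2c(ccc(F)c2F)C1(c1ccc(O)cc1)c1ccc(F)cc1` gives 2.6 nM
compound 2 `Cc1ccc(C2(c3ccc(O)cc3)C(=O)Nc3c2ccc(F)c3F)cc1` gives 1.7 nM
compound 3 `COc1ccc(C2(c3cccc(O)c3)C(=O)Nc3c2ccc(F)c3F)cc1` gives 196 nM

Compound 1 belongs to the low end of these numbers. It is level with compound 2 within the scatter, and well under compound 3 at 196 nM.

The unmeasured compound 4 `O=C1Nc2c(ccc(F)c2F)C1(c1ccc(O)cc1)c1cccnc1` keeps the core of compound 1 and changes one group, with pyridin-3-yl in place of 4-fluorophenyl on a saturated ring carbon.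

Within the data shown here, only one measured step touches the ring that leaves here, and it is small: a 1.5-fold lower number from compound 1 to compound 2 (0.18 log units; within the scatter). That step keeps the ring and alters only the group on it, so it says little about replacing the whole ring. Compound 3 differs from compound 1 in more than one place, so its value cannot be tied to any single change. Among the measured compounds shown here, no measured step puts a ring with a hetero atom in this place, which leaves the estimate loose.

With compound 1 at 2.6 nM, a moderate rise towards a weaker inhibitor seems the likelier outcome, though no change at all remains possible. The expected change is a 3.8-fold higher number from compound 1 to compound 4 (0.59 log units; beyond the scatter). For compound 4 the estimated value is 10 nM, with an expected range from 2.5 nM to 50 nM.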

Compound 4, half-maximal inhibitory concentration: 63 nM
The estimate for compound 4 lay 6.3-fold (0.80 log units) below the measured number, and the stated range ends below it.
By their numbers in this assay, from the lowest: compounds 2 and 1 (each within the scatter of the next); then compound 4; then compound 3.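

In this assay, the swap of 4-fluorophenyl for pyridin-3-yl gives a 24-fold higher number from compound 1 to compound 4 (1.38 log units; beyond the scatter), and the swap of 4-methylphenyl for the same ring gives a 37-fold higher number from compound 2 to compound 4 (1.57 log units; beyond the scatter). Among these compounds, the only earlier step at this place, a 1.5-fold lower number from compound 1 to compound 2 (0.18 log units; within the scatter), changed just the group on a carbon-only ring, whereas these new steps show that the place on the saturated ring carbon does not tolerate every six-membered aromatic ring: among compounds 1, 2 and 4, the two with a carbon-only ring sit within the scatter of each other, and the ring with one hetero atom stands far from both. Nothing measured here explains why the number rises so steeply.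

Two things change at once in these steps, since the ring gains a nitrogen and also loses its substituent, so a plain phenyl group would show which of the two goes with the rise. Pyridin-4-yl or 6-fluoropyridin-3-yl at the same place would further show whether the position of the nitrogen or the return of a fluorine alters the result.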